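The source may report more compounds than this note shows. Statements on the series, on what has been measured and on what is new or still open speak of the compounds shown alone.

Compound 1 `O=C(C1=C(O)C(=O)N(CCCn2ccnc2)C1c1ccc(Br)cc1)c1ccccc1` gives 73100 nM in a functional assay on A549 cells (Homo sapiens) for antiproliferative activity, read by MTT assay, with a stated time of 72 h; on this read-out lower numbers stand for stronger inhibition and higher numbers for weaker inhibition.
Compound 2 `O=C(C1=C(OC2CCCCC2)C(=O)N(CCCn2ccnc2)C1c1ccc(Br)cc1)c1ccccc1` gives 31200 nM in this assay.
Compound 3 `O=C(C1=C(Nc2ccccc2)C(=O)N(CCCn2ccnc2)C1c1ccc(Br)cc1)c1ccccc1` gives 24100 nM in this assay.

Compound 3 shows the lowest of these three numbers, though only its gap to compound 1 is clear: the step of a 3.0-fold lower number from compound 1 to compound 3 (0.48 log units; beyond the scatter) lies beyond the scatter, whereas the step of a 1.3-fold lower number from compound 2 to compound 3 (0.11 log units; within the scatter) does not, so compound 3 and compound 2 cannot be told apart. Compound 4 `O=C(C1=C(Nc2ccc(I)cc2)C(=O)N(CCCn2ccnc2)C1c1ccc(Br)cc1)c1ccccc1` keeps the whole of compound 3 except for one change: iodo in place of hydrogen on an aromatic carbon. Within the data shown here, none of the measured steps touches this place. The steps of a 2.3-fold lower number from compound 1 to compound 2 (0.37 log units; beyond the scatter) and a 3.0-fold lower number from compound 1 to compound 3 (0.48 log units; beyond the scatter) concern the group on the double-bonded ring carbon, and the step of a 1.3-fold lower number from compound 2 to compound 3 (0.11 log units; within the scatter) swaps one such group for another; none alters the phenyl of the anilino group. There is thus no direct guide, and an added iodo on that ring is expected to bring a change within the scatter or at most a modest one: a 1.6-fold lower number from compound 3 to compound 4 (0.21 log units; within the scatter). Compound 4 is therefore estimated at 15000 nM, with a likely range from 5000 nM to 45000 nM.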

Compound 4, half-maximal inhibitory concentration: 24500 nM
The estimate for compound 4 lay 1.6-fold (0.21 log units) below the measured number, and the stated range covers the measured number.
By their numbers in this assay, from the lowest: compounds 3, 4 and 2 (each within the scatter of the next); then compound 1.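

Changing the phenyl of the anilino group to 4-iodophenyl gives no readable change in this assay, since a 1.0-fold higher number from compound 3 to compound 4 (0.01 log units; within the scatter) stays within the scatter, so this ring can carry an iodine atom without a measurable shift in the number. The (4-iodophenyl)amino group also stands where anilino stood relative to the other compounds: a 1.3-fold lower number from compound 2 to compound 4 (0.10 log units; within the scatter) cannot be told apart from no change, while a 3.0-fold lower number from compound 1 to compound 4 (0.47 log units; beyond the scatter) remains a modest step beyond the scatter. Nothing measured here bears on the reason for this result.

A single iodo at one spot cannot show whether this ring tolerates every group, so a methoxy, an amine or a carboxylic acid in that place could still move the number. As far as these compounds go, whether any change on this ring can bring the number clearly below that of compound 3 also stays open.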